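The source may report more compounds than this note shows. Statements on the series, on what has been measured and on what is new or still open speak of the compounds shown alone.

Compound 1 `CCOC(=O)c1c(-c2cccc(C(F)(F)F)c2)[nH]c2cc(OC)ccc2c1=O` gives 19000 nM in a physicochemical assay for solubility, in phosphate buffer, at pH 7.4 (on this read-out higher numbers stand for higher solubility and lower numbers for lower solubility), the lowest of the two numbers shown there. Compound 2 `CCOC(=O)c1c(-c2cccc([N+](=O)[O-])c2)[nH]c2cccc(OC)c2c1=O` gives 49000 nM in this assay, a step beyond the scatter above compound 1. Compound 3 `CCOC(=O)c1c(-c2cccc(C(F)(F)F)c2)[nH]c2cccc(OC)c2c1=O` gives > 100000 nM in this assay, which is a limit of the assay rather than a number. Among the measured compounds shown here, the only measured step that bears on the present question is an at least 2.0-fold higher number from compound 2 to compound 3 (0.30 log units; that floor lies within the scatter), whose true size stays open because its upper end sits at the limit of > 100000 nM in this assay, at which 1 of the 3 values shown sits. Compound 4 `CCOC(=O)c1c(-c2cccc([N+](=O)[O-])c2)[nH]c2cc(OC)ccc2c1=O` differs from compound 1 by nitro in place of trifluoromethyl on an aromatic carbon, the reverse of that step. A lower number is therefore expected for compound 4, by about a 2.0-fold lower number from compound 1 to compound 4 (0.30 log units; within the scatter), a shift that may not clear the scatter. The estimate for compound 4 in this assay is 9500 nM, between 4000 nM and 25000 nM.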

Compound 4, solubility: 13000 nM
For compound 4 the middle estimate is 1.4-fold (0.14 log units) below the measured one, within the range that was stated.
By their numbers in this assay, from the lowest: compounds 4 and 1 (each within the scatter of the next); then compound 2. At a limit, above all of these: compound 3.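

In this assay the change gives a 1.5-fold lower number from compound 1 to compound 4 (0.16 log units; within the scatter), so on the core of compound 1 nitro and trifluoromethyl on this aromatic carbon are not told apart. Unlike the earlier step, this one has a number at both ends and can be read in full. The same change on the core of compound 2 stays unsized, as compound 3 gives a limit and not a number: the limit of > 100000 nM in this assay, at which 1 of the 4 values shown sits.

Open, from the compounds shown here alone, is whether another group at this place, such as an amine or a carboxylic acid, would shift the number beyond the scatter.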